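The source may report more compounds than this note shows. Statements on the series, on what has been measured and on what is new or still open speak of the compounds shown alone.

In a functional assay on HeLa cells (Homo sapiens) for cytotoxicity, read by MTT assay, with a stated time of 48 h (on this read-out higher numbers stand for weaker inhibition and lower numbers for stronger inhibition), three compounds that share one core have been measured so far, each differing only in the group on one aromatic carbon of the outer benzene ring. Compound 1 `Cc1ccc(Cn2cc(COc3ccc4c(=O)ccoc4c3)nn2)cc1` carries a methyl there; in this assay compound 1 gives > 100000 nM, which is a limit of the assay and not a number (the limit of > 100000 nM in this assay, at which 1 of the 3 values shown sits). Compound 2 `O=c1ccoc2cc(OCc3cn(Cc4ccc(F)cc4)nn3)ccc12` carries a fluoro and gives 12000 nM. Compound 3 `CC(C)(C)c1ccc(Cn2cc(COc3ccc4c(=O)ccoc4c3)nn2)cc1` carries a tert-butyl and gives 17600 nM, the higher of the two real numbers, though the step between these two is a 1.5-fold higher number from compound 2 to compound 3 (0.17 log units; within the scatter). Going from the methyl, the steps were an at least 8.3-fold lower number from compound 1 to compound 2 (0.92 log units; beyond the scatter) and an at least 5.6-fold lower number from compound 1 to compound 3 (0.75 log units; beyond the scatter).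

Compound 4 `O=c1ccoc2cc(OCc3cn(Cc4ccc([N+](=O)[O-])cc4)nn3)ccc12` is the next change on that carbon: nitro in place of tert-butyl on an aromatic carbon. Within the data shown here, the only measured step that swapped one such group for another without passing through the limit, a 1.5-fold higher number from compound 2 to compound 3 (0.17 log units; within the scatter), stayed within the scatter, so no step beyond the scatter is expected here either; the expected step is a 1.2-fold lower number from compound 3 to compound 4 (0.07 log units; within the scatter). Compound 4 is therefore estimated at 15000 nM, within 5000 nM to 50000 nM.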

Compound 4, half-maximal inhibitory concentration: 25700 nM
Beside the measured number, compound 4's estimate is 1.7-fold (0.23 log units) below it; the range from low to high includes it.
By their numbers in this assay, from the lowest: compounds 2, 3 and 4 (each within the scatter of the next, the first and the last beyond it). At a limit, above all of these: compound 1.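

In this assay, replacing tert-butyl with nitro on this aromatic carbon, para to a large group, gives a 1.5-fold higher number from compound 3 to compound 4 (0.16 log units; within the scatter), even though the two groups differ in their atoms and only nitro has hydrogen-bond acceptors. Among these compounds, the first step beyond the scatter between two real numbers is modest, a 2.1-fold higher number from compound 2 to compound 4 (0.33 log units; beyond the scatter), while nitro also keeps the clear separation from methyl seen with the other two groups, an at least 3.8-fold lower number from compound 1 to compound 4 (0.59 log units; beyond the scatter). The value for compound 1 is a limit and not a number, so the true size of that last step stays unknown: the limit of > 100000 nM in this assay, at which 1 of the 4 values shown sits.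

The compounds shown leave open whether an amine or a carboxylic acid on this carbon would fall in the same range. They also leave open whether an ethyl group, or a longer chain, would behave like methyl or like tert-butyl.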